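From Hydroxy to 3-Bromopropoxy on the Shared Core

The source may report more compounds than this note shows. Statements on the series, on what has been measured and on what is new or still open speak of the compounds shown alone.

Compound 1 `COc1ccc(N(C)c2ccnc(Cl)n2)cc1` gives 917 nM
Compound 2 `COc1ccc(N(C)c2ccnc(Cl)n2)cc1O` gives 96 nM

In a functional assay on HeLa cells (Homo sapiens) for antiproliferative activity, read by MTT assay, with a stated time of 48 h (on this read-out higher numbers stand for weaker inhibition and lower numbers for stronger inhibition), compound 2 holds the lower of these two numbers. Compound 3 `COc1ccc(N(C)c2ccnc(Cl)n2)cc1OCCCBr` differs from it by 3-bromopropyl in place of hydrogen on an oxygen on an aromatic ring with 3-bromopropyl in place of hydrogen on an oxygen on an aromatic ring. Among the measured compounds shown here, the one measured step that bears on this is a 9.6-fold lower number from compound 1 to compound 2 (0.98 log units; beyond the scatter) with hydroxy in place of hydrogen on an aromatic carbon. For the measured compounds named here, compound 3 loses that hydroxy hydrogen, so part of this modest step is expected to be reversed, although no measured compound carries the new chain. The expected change is a 3.6-fold higher number from compound 2 to compound 3 (0.56 log units; beyond the scatter) toward a higher number. The estimate for compound 3 is 350 nM with an expected range from 80 nM to 1500 nM in this read-out.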

Compound 3, half-maximal inhibitory concentration: 307 nM
For compound 3 the middle estimate is 1.1-fold (0.06 log units) above the measured one; the range from low to high includes it.
By their numbers in this assay, from the lowest: compound 2; then compound 3; then compound 1.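

Read in this assay, putting 3-bromopropyl on this oxygen gives a 3.2-fold higher number from compound 2 to compound 3 (0.50 log units; beyond the scatter), so the oxygen on the aromatic ring can carry a chain at a measurable cost. The substituted position still keeps part of its gain, with 3-bromopropoxy giving a 3.0-fold lower number from compound 1 to compound 3 (0.48 log units; beyond the scatter) in place of hydrogen on the aromatic carbon. Nothing shown here accounts for either step.

The compounds shown leave open whether the chain or its terminal bromine sets this number. They also leave open how a plain propoxy chain, or a propoxy chain ending in an amine, would compare.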